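A few compounds are considered here, and "the series" means these few. Any claim that something is new, unique, unknown or untested is made for them only; others in the source may bear on it.

Three compounds sharing one core have been run in an assay on isolated protein for inhibition of hexokinase-2 (Rattus norvegicus), with a stated time of 6 h, tested at 10 mM; on this read-out lower numbers stand for less inhibition and higher numbers for more inhibition at the one concentration tested (going by the name of the read-out). Compound 1 `Nc1ncnc2c1nc(NCCCCCCCCNC(=O)CI)n2[C@@H]1O[C@H](COP(=O)(O)OP(=O)(O)OP(=O)(O)O)[C@@H](O)[C@H]1O` gives 0%. Compound 2 `O=C(CI)NCCCNc1ncnc2c1ncn2[C@@H]1O[C@H](COP(=O)(O)OP(=O)(O)OP(=O)(O)O)[C@@H](O)[C@H]1O` gives 0%, and compound 3 `O=C(CI)NCCCCCCC(=O)NCCCNc1ncnc2c1ncn2[C@@H]1O[C@H](COP(=O)(O)OP(=O)(O)OP(=O)(O)O)[C@@H](O)[C@H]1O` gives 0%. Compound 2 therefore stands level with compound 1 and compound 3 at the digits shown; its nearest neighbour on the numbers is compound 1 and its furthest is compound 3, both within the scatter. Among the compounds with values here, only one pair differs in a single place: 5-(((iodomethyl)carbonyl)amino)pentyl in place of iodo on a saturated chain carbon bound to a carbonyl carbon.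

Compound 4 `O=C(I)NCC(=O)NCCCCCCNc1ncnc2c1ncn2[C@@H]1O[C@H](COP(=O)(O)OP(=O)(O)OP(=O)(O)O)[C@@H](O)[C@H]1O` has not yet been measured. It differs from compound 2 as follows: a group of 11 heavy atoms (6 carbon, 2 nitrogen, 2 oxygen, 1 iodine; no ring) in place of a group of 5 heavy atoms (2 carbon, 1 nitrogen, 1 oxygen, 1 iodine; no ring), on a saturated chain carbon, three bonds along the chain from a nitrogen on an aromatic ring. Within the data shown here, the only measured step that bears on this change, a lengthening of the chain carrying the iodine-bearing end, gave no change at the digits printed from compound 2 to compound 3 (within the scatter). Among the measured compounds shown here, no other step is available, and all three measured values sit at the bottom of the read-out. The expectation for compound 4 in this assay is accordingly a step of no change at the digits printed from compound 2 to compound 4 (within the scatter) from compound 2, that is, none beyond the scatter. Compound 4 is thus estimated at 0%, with a range from 0% to 10%.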

Compound 4, a percentage reported as inhibition, at one concentration (the size of the read-out at that concentration, not a potency): 0%
The estimate for compound 4 equals the measured number at the digits printed; low and high end bracket the measured number.
By their numbers in this assay, from the lowest: compounds 1, 2, 3 and 4 (each within the scatter of the next).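

In this assay the group of 11 heavy atoms (6 carbon, 2 nitrogen, 2 oxygen, 1 iodine) replaces ((iodomethyl)carbonyl)amino on a saturated chain carbon, three bonds along the chain from a nitrogen on an aromatic ring, and the read-out shows no change at the digits printed from compound 2 to compound 4 (within the scatter) at this position. Within the data shown here, the entering group carries 2 hydrogen-bond donors and 2 hydrogen-bond acceptors where the leaving group carries 1 of each, so this second enlargement of the side chain, a different replacement from the one giving no change at the digits printed from compound 2 to compound 3 (within the scatter) in the same assay, also brings no inhibition into view. No measurement on hand bears on why this change leaves the read-out unmoved.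

All the compounds shown sit at the bottom of the read-out, so the values cannot separate these side chains from one another, and whether any of them has a smaller effect than another remains unresolved. Going by these compounds, whether an amine or a carboxylic acid in place of the iodine-bearing end, or a longer chain at this position, would lift this assay off the bottom remains open.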